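The source may hold more compounds than are shown below. What is called first, only, known or untested is meant among the compounds shown, and "the series" means these compounds.

Of the compounds shown here, three built on the same core have been tested in a functional assay on KB cells (Homo sapiens) for cytotoxicity; a lower number here means that less compound is needed, a higher number that more compound is needed for the effect. Compound 1 `CCC[C@@H](OC(C)=O)C1=C(Br)/C(=C/Br)OC1=O` gives 1 ug/mL in this assay. Compound 2 `CCC[C@@H](OC(C)=O)C1=C(Br)C(=C(Br)Br)OC1=O` gives 3.5 ug/mL, and compound 3 `CCC[C@@H](OC(C)=O)C1=C(Br)[C@@](OC)(C(Br)Br)OC1=O` gives 6.2 ug/mL. Among these three numbers compound 2 stands second highest. Its nearest neighbour is compound 3, whose number lies within the usual scatter of repeated measurements, so the two cannot be told apart. Compound 1 lies furthest away, with a number that is lower by more than the scatter. No two of the measured compounds differ in only one place, so none of them shows on its own what a single structural change does here.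

Compound 4 `CCC[C@@H](O)C1=C(Br)C(=C(Br)Br)OC1=O` has not yet been measured. It differs from compound 2 in one place: hydrogen in place of acetyl on an oxygen on a saturated carbon. Going by the values given here, no measured pair shows the effect of this change on this core, so the expectation rests only on the narrow spread of numbers already seen. For compound 4 the expected step is a 1.4-fold higher number from compound 2 to compound 4 (0.15 log units; within the scatter), a small move upward, though no move beyond the scatter would be no surprise either. For compound 4 in this assay the estimate is 5 ug/mL, with a likely range from 1.5 ug/mL to 15 ug/mL.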

Compound 4, concentration for half-maximal effect: 9.5 ug/mL
Compound 4: middle estimate off by 1.9-fold (0.28 log units), on the low side; the range from low to high includes it.
By their numbers in this assay, from the lowest: compound 1; then compounds 2, 3 and 4 (each within the scatter of the next, the first and the last beyond it).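

In this assay, the change from acetoxy to hydroxy on the saturated carbon gives a 2.7-fold higher number from compound 2 to compound 4 (0.43 log units; beyond the scatter), so more compound is needed for the effect once the acetyl is gone. Going by these compounds alone, this is the first comparison here in which only one place differs, and it shows that the group on this oxygen is not a silent passenger on the shared core. Within the data shown here, the step is modest, but it shows that the acetyl can be removed only at some cost in this read-out, something the earlier compounds, which all carry the acetoxy group and differ elsewhere, could not show. No measurement here explains why the number moves.

Whether the acetyl matters as an ester in particular, or whether another group on this oxygen would serve as well, stays open, since a methyl ether or a longer ester such as butyrate is not among the compounds shown. From the compounds shown here alone, it is also open whether removing the acetyl would move the number in the same direction and by a similar amount in compound 1 or compound 3.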